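The source may report more compounds than this note shows. Statements on the series, on what has been measured and on what is new or still open speak of the compounds shown alone.

Compound 2, `Cc1nc2ccc(Br)cc2c(=O)n1NCc1nnc(/N=C/c2ccccc2)s1`, gives 50% in a functional assay on the whole organism (strain albino) with Rattus norvegicus as the target, in the maximal electroshock model, with a stated time of 1 h, at a dose of 30 mg/kg by the intraperitoneal route (a higher number here means more inhibition at the dose given (going by the name of the read-out), a lower number less inhibition), and stands level with compound 1, `COc1ccc(/C=N/c2nnc(CNn3c(C)nc4ccc(Br)cc4c3=O)s2)cc1`, which gives 50% in this assay. For the measured compounds named here, the one measured step between these two, no change at the digits printed from compound 1 to compound 2 (within the scatter), stays within the scatter. Compound 3, `COc1cc(/C=N/c2nnc(CNn3c(C)nc4ccc(Br)cc4c3=O)s2)ccc1O`, differs from compound 2 in one place: 4-hydroxy-3-methoxyphenyl in place of phenyl on a carbon with a double bond to nitrogen. Going by the values given here, only the step from compound 1 to compound 2 bears on this change, and it moved nothing beyond the scatter, so no step beyond the scatter is expected, no change at the digits printed from compound 2 to compound 3 (within the scatter). Compound 3 is therefore estimated at 50%, in the range 30% to 70%.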

Compound 3, a percentage reported as inhibition, in the whole organism at one dose (the size of the read-out at that dose, not a potency): 50%
For compound 3 middle estimate and measured number coincide at the digits printed; low and high end bracket the measured number.
By their numbers in this assay, from the lowest: compounds 1, 2 and 3 (each within the scatter of the next).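

In this assay the step to 4-hydroxy-3-methoxyphenyl on a carbon with a double bond to nitrogen, in place of phenyl, gives no change at the digits printed from compound 2 to compound 3 (within the scatter). In place of 4-methoxyphenyl, the same group gives no change at the digits printed from compound 1 to compound 3 (within the scatter), so at this position a group with a hydrogen-bond donor now also stands level with the two groups without one. Nothing at hand bears on why these values coincide.

The compounds shown leave open whether that level holds with an aromatic ring carrying an amine or a carboxylic acid on this carbon. On these data alone, they also share one core, so the effect of any change there stays open.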